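A few compounds are considered here, and "the series" means these few. Any claim that something is new, unique, unknown or untested is made for them only; others in the source may bear on it.

Compound 1 `COc1cc(C2CC(c3cccc4ccccc34)=NN2C(C)=O)ccc1OCc1cn(Cc2ccc([N+](=O)[O-])cc2)nn1` gives 95% in a functional assay on A549 cells (Homo sapiens) for inhibition, read by sulforhodamine B assay, tested at 100 uM (a higher number here means more inhibition of growth at the concentration tested, a lower number less inhibition of growth), the highest of the three values here: compound 3 `CC(=O)N1N=C(c2ccc(OCc3cn(Cc4ccc([N+](=O)[O-])cc4)nn3)cc2)CC1c1ccccc1` gives 80%, and compound 2 `COc1ccc(C2CC(c3ccc(OCc4cn(Cc5ccc([N+](=O)[O-])cc5)nn4)cc3)=NN2C(C)=O)cc1` gives 33%. Compound 4 `COc1cc(C2CC(c3ccccc3)=NN2C(C)=O)ccc1OCc1cn(Cc2ccc([N+](=O)[O-])cc2)nn1` differs from compound 1 by phenyl in place of naphthalen-1-yl on a carbon with a double bond to nitrogen. For the measured compounds named here, the only measured step, a number 47 percentage points higher from compound 2 to compound 3 (beyond the scatter), concerns a different change, hydrogen in place of methoxy on an aromatic carbon, so it does not bear on this one. Going by the values given here, no measured pair changes only the group on the carbon with a double bond to nitrogen. Without a direct guide, a moderate fall in this assay is expected, roughly a number 20 percentage points lower from compound 1 to compound 4 (beyond the scatter). Compound 4 is therefore estimated at 75%, in a range from 45% to 95%.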

Compound 4, percent growth inhibition at one concentration: 11%
Estimate against measurement, compound 4: 64 percentage points above, outside the stated range (below it).
By their numbers in this assay, from the lowest: compound 4; then compound 2; then compound 3; then compound 1.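

Putting phenyl in place of naphthalen-1-yl on the carbon with a double bond to nitrogen gives a number 84 percentage points lower from compound 1 to compound 4 (beyond the scatter) in this assay. For the compounds shown here, this is the first measured sign that the group at this position strongly affects the read-out, since the one earlier step concerned a methoxy group elsewhere. It also shows that, on the core of compound 1, the second aromatic ring of naphthalen-1-yl goes with far more growth inhibition. Nothing available explains this drop. Going by these compounds, whether naphthalen-2-yl, cyclohexyl or an amine at this position would preserve the inhibition remains open.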